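A few compounds are considered here, and "the series" means these few. Any claim that something is new, unique, unknown or untested is made for them only; others in the source may bear on it.

Of the compounds shown here, three built on one shared core have been measured in an assay on CHO cells for displacement of a labelled ligand from C-X-C chemokine receptor type 1 (Homo sapiens); a lower number here means a stronger inhibitor, a higher number a weaker inhibitor. Compound 1 `CCc1coc([C@@H](CC)Nc2c(Nc3cccc(C(=O)N(C)C)c3O)c(=O)c2=O)c1` gives 7 nM. Compound 2 `CC[C@@H](Nc1c(Nc2cccc(C(=O)N(C)C)c2O)c(=O)c1=O)c1cc(C(C)C)co1` gives 3 nM, the lowest of the three numbers, with compound 1 nearest to it and compound 3 furthest. Compound 3 `CCC(C)c1coc([C@@H](CC)Nc2c(Nc3cccc(C(=O)N(C)C)c3O)c(=O)c2=O)c1` gives 7.6 nM. The steps among these three all sit at a saturated chain carbon bound to an aromatic carbon and a saturated chain carbon: a 2.3-fold lower number from compound 1 to compound 2 (0.37 log units; beyond the scatter), a 1.1-fold higher number from compound 1 to compound 3 (0.04 log units; within the scatter) and a 2.5-fold higher number from compound 2 to compound 3 (0.40 log units; beyond the scatter).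

Compound 4 `CC(C)c1coc([C@H](Nc2c(Nc3cccc(C(=O)N(C)C)c3O)c(=O)c2=O)C2CC2)c1` differs from compound 2 at a different place: cyclopropyl in place of ethyl on a saturated chain carbon bound to an aromatic carbon and a nitrogen on an aromatic ring. Within the data shown here, none of the measured steps touches that position, so they offer no direct guide to this change; they show only that the variations seen so far in this assay have stayed modest. Among the measured compounds shown here, with no bearing step available, compound 4 is expected to remain close to its parent in this assay, and the step of a 1.2-fold higher number from compound 2 to compound 4 (0.07 log units; within the scatter) is expected to fall within the scatter. The estimate for compound 4 in this assay is 3.5 nM, with a range from 1.2 nM to 10 nM.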

Compound 4, inhibition constant: 10 nM
The estimate for compound 4 lay 2.9-fold (0.46 log units) below the measured number; the range from low to high includes it.
By their numbers in this assay, from the lowest: compound 2; then compounds 1, 3 and 4 (each within the scatter of the next).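

In this assay, among these compounds, there is a 3.3-fold higher number from compound 2 to compound 4 (0.52 log units; beyond the scatter) and this shows that the saturated chain carbon bound to an aromatic carbon and a nitrogen on an aromatic ring is a place where the substituent affects the number, something the earlier compounds could not show because all of them carry ethyl there. At this place, cyclopropyl in place of ethyl gives a modest loss of potency, beyond the scatter. No measurement at hand accounts for this loss.

From the compounds shown here alone, with only ethyl and cyclopropyl seen at this place, it remains open whether the loss follows the ring or simply the larger count of carbon. A methyl, an isopropyl or a cyclobutyl group there would help to separate the two, and the same swap on the core of compound 1 would show whether the step carries over.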